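This account rests on a few compounds, and the source may have more. Where it says the series, first, only, none or still open, it means among the compounds named here.

Measured in a functional assay on cells (Neutrophil, Homo sapiens) for activation, read by luminescence, with a stated time of 60 min; on this read-out lower numbers stand for an effect already at smaller amounts and higher numbers for an effect only at larger amounts of compound:

Compound 1 `COc1cccc(Cc2cc(C(C)C)nn(CC(=O)Nc3ccc(Br)cc3)c2=O)c1`: 700 nM
Compound 2 `COc1cccc(Cc2cc(C3CCCCC3)nn(CC(=O)Nc3ccc(Br)cc3)c2=O)c1`: 2500 nM
Compound 3 `Cc1cc(Cc2cccc(F)c2)c(=O)n(CC(=O)Nc2ccc(Br)cc2)n1`: 1900 nM

Compound 3, at 1900 nM, lies within the usual scatter of compound 2, and its number is clearly higher than that of compound 1. Compound 4 `Cc1cc(Cc2cccs2)c(=O)n(CC(=O)Nc2ccc(Br)cc2)n1` has thiophen-2-yl in place of 3-fluorophenyl on a saturated chain carbon bound to an aromatic carbon. Within the data shown here, no measured step involves this change. The only one, a 3.6-fold higher number from compound 1 to compound 2 (0.55 log units; beyond the scatter), is modest and swaps cyclohexyl for isopropyl on an aromatic carbon, so it indicates no direction here. In this assay, no step beyond the scatter is therefore expected. The estimated change is a 1.2-fold lower number from compound 3 to compound 4 (0.07 log units; within the scatter). Compound 4 is expected at 1600 nM, with an estimated range of 600 nM to 4200 nM.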

Compound 4, half-maximal effective concentration: 3900 nM
Estimate against measurement, compound 4: 2.4-fold (0.39 log units) below, within the range that was stated.
By their numbers in this assay, from the lowest: compound 1; then compounds 3, 2 and 4 (each within the scatter of the next, the first and the last beyond it).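

Putting thiophen-2-yl in place of 3-fluorophenyl on a saturated chain carbon bound to an aromatic carbon gives a 2.1-fold higher number from compound 3 to compound 4 (0.31 log units; beyond the scatter) in this assay, so this position does respond to a change of ring, though only modestly. Among these compounds, the only earlier step concerned a different place, the swap of isopropyl for cyclohexyl on an aromatic carbon. Nothing available gives a reason for this new step.

Going by these compounds, it remains open whether plain phenyl would separate the part played by the fluorine from that of the ring. Also open, on these data alone, is how a group carrying an amine or a carboxylic acid would read at this place.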